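Chloro to fluoro exchange: expected inhibition of compound 3

A few compounds are considered here, and "the series" means these few. Any claim that something is new, unique, unknown or untested is made for them only; others in the source may bear on it.

Measured compounds:
compound 1, `Cn1cc(C(=O)c2ccc(Cl)cc2)cc1/C=C/C(=O)NO`: 87%
compound 2, `Cn1cc(C(=O)c2ccccc2)cc1/C=C/C(=O)NN`: 0.2%

Compound 1 stands highest of the two numbers in an assay on isolated protein for inhibition of histone deacetylase HD2 (Zea mays), tested at 30 uM; on this read-out higher numbers stand for more inhibition at the one concentration tested (going by the name of the read-out) and lower numbers for less inhibition; the nearest, compound 2, lies lower by a gap beyond the scatter. Among the compounds with values here, compound 2 differs from compound 1 in more than one place, so the pair shows only that compound 1 inhibits strongly at the concentration tested while compound 2 shows essentially none.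

Compound 3, `Cn1cc(C(=O)c2ccc(F)cc2)cc1/C=C/C(=O)NO`, is still to be measured in this assay. It differs from compound 1 by fluoro in place of chloro on an aromatic carbon. Within the data shown here, no pair of measured compounds shares this change, so no measured step guides it. A small step is expected, from compound 1 to compound 3, lying within the scatter or a little downward: a number 7 percentage points lower from compound 1 to compound 3 (within the scatter). Compound 3 is therefore estimated at 80%, with a range of 60% to 95%, because compound 1 already gives 87%.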

Compound 3, a percentage reported as inhibition, at one concentration (the size of the read-out at that concentration, not a potency): 84%
Compound 3: the middle estimate sits 4 percentage points below what was measured, within the range that was stated.
By their numbers in this assay, from the lowest: compound 2; then compounds 3 and 1 (each within the scatter of the next).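

In this assay, within the data shown here, the exchange of 4-chlorophenyl to 4-fluorophenyl gives a number 3 percentage points lower from compound 1 to compound 3 (within the scatter) and is the first change that can be read in one place alone. The earlier pair differed in more than one place and said nothing about this position; here, on an aromatic carbon para to a large group, fluoro and chloro cannot be told apart at the one concentration tested. Nothing on hand gives a reason for this result.

Still open, as far as these compounds go, is whether this position holds up with a group other than a halogen, such as an amine, a methoxy group or a carboxylic acid. Also open, from the compounds shown here alone, is what the end of the side chain contributes alone, which a carboxylic acid there, with the 4-chlorophenyl kept, would isolate.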